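The source may hold more compounds than are shown below. What is called first, only, known or untested is meant among the compounds shown, and "the series" means these compounds.

Among the measured compounds shown here, compound 2, `CSCc1c(C)nc2c(OCc3ccccc3)cccn12`, gives 8% in a functional assay on the whole organism (stomach) for inhibition, with Canis familiaris (Canis lupus familiaris) as the target, at a dose of 5 mg/kg by the intravenous route (a higher number here means a stronger effect of the compound at the dose given, a lower number a weaker effect), and stands lowest of the two numbers measured so far. Its nearest neighbour is compound 1, `COCc1c(C)nc2c(OCc3ccccc3)cccn12`, which in this assay gives 29%. For the measured compounds named here, the only step available runs between these two: a number 21 percentage points lower from compound 1 to compound 2 (beyond the scatter), a change that put methylsulfanyl in place of methoxy on a saturated chain carbon bound to an aromatic carbon.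

The step from compound 2 to compound 3, `CC(=O)OCc1c(C)nc2c(OCc3ccccc3)cccn12`, reverses part of that move and goes further: acetoxy in place of methylsulfanyl on a saturated chain carbon bound to an aromatic carbon. Going by the values given here, the one measured step bears on it only indirectly, since it shows that exchanging an oxygen-bearing group for methylsulfanyl at this carbon lowered the inhibition beyond the scatter; returning to an oxygen-bearing group, here acetoxy, might recover some of that loss, but the acetoxy group is not the methoxy group, so the size is uncertain.

He therefore expects compound 3 to move upward, by about a number 16 percentage points higher from compound 2 to compound 3 (beyond the scatter) in this assay. His estimate for compound 3 is 24%, within a range from 5% to 45%.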

Compound 3, a percentage reported as inhibition, in the whole organism at one dose (the size of the read-out at that dose, not a potency): 87%
Beside the measured number, compound 3's estimate is 63 percentage points below it, and the stated range ends below it.
By their numbers in this assay, from the lowest: compound 2; then compound 1; then compound 3.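

In this assay the exchange of methylsulfanyl for acetoxy on a saturated chain carbon bound to an aromatic carbon gives a number 79 percentage points higher from compound 2 to compound 3 (beyond the scatter). This shows that this place can carry a far larger change in the read-out than the earlier step between compound 1 and compound 2 revealed. An oxygen on this carbon is not enough by itself to reach that level, since acetyl in place of methyl on that oxygen still gives a number 58 percentage points higher from compound 1 to compound 3 (beyond the scatter) and this step too is large. Nothing shown here accounts for the height of compound 3 over the other two compounds.

From the compounds shown here alone, it remains open whether the large rise belongs to the acetoxy group in particular or would also appear with a free hydroxyl, a longer ester such as propanoyloxy, or an amine on this carbon. As every number comes from a single intravenous dose, the compounds shown also leave open how compound 3 would compare with compound 1 and compound 2 at other doses.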